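A few compounds are considered here, and "the series" means these few. Any claim that something is new, unique, unknown or untested is made for them only; others in the source may bear on it.

Of the compounds shown here, three sharing one core have been tested in a functional assay on HCT-15 cells (Homo sapiens) for antiproliferative activity, read by sulforhodamine B assay; on this read-out higher numbers stand for weaker inhibition of growth and lower numbers for stronger inhibition of growth. Compound 1 `CC(C)CCCOc1cccc(O)c1C(=O)/C=C/c1ccc(O)cc1` gives a measured 11600 nM. For compound 2 `COc1cccc(OCCC(C)(C)C)c1C(=O)/C=C/c1ccc(O)cc1`, the result is only a limit, > 30000 nM. For compound 3 `O=C(/C=C/c1ccc(O)cc1)c1c(O)cccc1OCC1CCCCC1`, the result is also only a limit, > 30000 nM. Compound 3 therefore stands at the limit of > 30000 nM in this assay, at which 2 of the 3 values shown sit.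

The next compound to consider is compound 4 `CC(C)COc1cccc(O)c1C(=O)/C=C/c1ccc(O)cc1`, which differs from compound 3 by one change: isopropyl in place of cyclohexyl on a saturated chain carbon bound to an oxygen on an aromatic ring. In words, this places isopropyl in place of cyclohexyl on a saturated chain carbon bound to an oxygen on an aromatic ring.

Among the compounds with values here, one measured step bears on this change. It is an at least 2.5-fold higher number from compound 1 to compound 3 (0.41 log units; beyond the scatter), seen when cyclohexyl took the place of isopentyl at the same place. Like compound 1, compound 4 has no ring in this group, so removing cyclohexyl may reverse at least part of that step. Isopropyl is a different group from isopentyl, however, so the match is only partial. The expected change is an at least 2.1-fold lower number from compound 3 to compound 4 (0.33 log units; beyond the scatter), a modest move towards stronger inhibition of growth. For compound 4, the estimated value is 14000 nM, with an expected range from 6000 nM to 30000 nM.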

Compound 4, concentration for 50% growth inhibition: 2600 nM
Compound 4: middle estimate off by 5.4-fold (0.73 log units), on the high side, and the stated range ends above it.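

In this assay, the group on the saturated chain carbon bound to an oxygen on an aromatic ring has a large effect: swapping cyclohexyl for isopropyl gives an at least 11-fold lower number from compound 3 to compound 4 (1.06 log units; beyond the scatter). The earlier compounds shown here showed only that cyclohexyl did worse than isopentyl, but the two groups without a ring also differ from each other, since isopropyl in place of isopentyl gives a 4.5-fold lower number from compound 1 to compound 4 (0.65 log units; beyond the scatter), so the absence of a ring does not by itself set the activity at this position. The value for compound 3 is only a limit, so the first step gives a minimum size, and its true size stays unknown: the limit of > 30000 nM in this assay, at which 2 of the 4 values shown sit.

The compounds shown do not reveal whether a smaller group such as ethyl would strengthen growth inhibition further or weaken it, or how a chain carrying an amine or a carboxylic acid would behave at this place. They also offer no explanation for why isopropyl outperforms both isopentyl and cyclohexyl. Compound 2 differs from the others in more than one place and cannot help here.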